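Three measured compounds and the next expected value

The source may report more compounds than this note shows. Statements on the series, on what has been measured and on what is new or still open speak of the compounds shown alone.

Compound 1 `CN(c1cccc2c1CN(c1nc(Nc3ccc(Nc4ccccc4)cc3)ncc1C(F)(F)F)C2)S(C)(=O)=O` gives 7300 nM
Compound 2 `CN(c1cccc2c1CN(c1nc(Nc3cccc(Oc4ccccc4)c3)ncc1C(F)(F)F)C2)S(C)(=O)=O` gives 4300 nM
Compound 3 `COc1cc(Nc2ncc(C(F)(F)F)c(N3Cc4cccc(N(C)S(C)(=O)=O)c4C3)n2)cc(OC)c1` gives 7000 nM

All of these numbers come from a functional assay on HeLa cells (Homo sapiens) for antiproliferative activity, read by spectrophotometry, with a stated time of 2 days (on this read-out higher numbers stand for weaker inhibition of growth and lower numbers for stronger inhibition of growth), and show only modest growth inhibition. Compound 3, at 7000 nM in this set, lies within the scatter of both compound 1 and compound 2, so the three cannot be ranked. They share a core and differ in the group carried on a nitrogen on an aromatic ring.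

Compound 4 `CN(c1cccc2c1CN(c1nc(Nc3cccc(C(F)(F)F)c3)ncc1C(F)(F)F)C2)S(C)(=O)=O` keeps the shared core of compound 3 and has 3-(trifluoromethyl)phenyl in place of 3,5-dimethoxyphenyl at that nitrogen (3-(trifluoromethyl)phenyl in place of 3,5-dimethoxyphenyl on a nitrogen on an aromatic ring). Among the compounds with values here, no measured pair isolates this exact change, so no step can be carried over directly. Still, the three different groups on that nitrogen leave compound 1 at 7300 nM and compound 2 at 4300 nM within the scatter of compound 3. On that limited basis, no step beyond the scatter is expected in this assay for this change. The estimated move is a 1.2-fold lower number from compound 3 to compound 4 (0.07 log units; within the scatter) and it is expected to remain within the scatter. For compound 4 the estimated value is 6000 nM with an expected range from 2500 nM to 15000 nM in this read-out.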

Compound 4, concentration for 50% growth inhibition: 5300 nM
Compound 4: the middle estimate sits 1.1-fold (0.05 log units) above what was measured, and the stated range covers the measured number.
By their numbers in this assay, from the lowest: compounds 2, 4, 3 and 1 (each within the scatter of the next).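

In this assay, within the data shown here, the exchange of 3,5-dimethoxyphenyl for 3-(trifluoromethyl)phenyl on a nitrogen on an aromatic ring gives a 1.3-fold lower number from compound 3 to compound 4 (0.12 log units; within the scatter) and is the first matched change at this position. The group that leaves counts 2 hydrogen-bond acceptors and the group that enters counts 0, yet the step stays within the scatter, so at this position and in these two compounds the read-out does not separate the two groups. Trifluoromethyl in place of phenoxy on an aromatic carbon gives a 1.2-fold higher number from compound 2 to compound 4 (0.09 log units; within the scatter) and is also within the scatter, and no available evidence explains why either exchange leaves the number so little changed.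

The compounds shown leave open whether a different kind of group on this aromatic ring, such as an amine or a carboxylic acid, would produce a step beyond the scatter. They also leave open whether a change elsewhere on the shared core, such as a nitrile in place of the trifluoromethyl on the core, would move the number further than any exchange at this nitrogen has done.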